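The compounds below may be only part of what the source reports. "The series", "measured", "known", "first", "only" and "open" are said of these compounds alone.

Three measured compounds share one core and a urea or amide on a side ring. Compound 1 `O=C(Nc1cccc(-n2cc(-c3ccncc3)c(-c3ccc(Cl)c(O)c3)n2)c1)Nc1ccc(Cl)c(Cl)c1` and compound 2 `COc1cc(-c2nn(-c3cccc(NC(=O)Nc4ccc(Cl)c(C(F)(F)F)c4)c3)cc2-c2ccncc2)ccc1Cl` both carry a urea; compound 3 `COc1cc(-c2nn(-c3cccc(NC(=O)c4ccccc4)c3)cc2-c2ccncc2)ccc1Cl` carries a benzamide instead. In a functional assay on SK-MEL-2 cells (Homo sapiens) for inhibition, read by sulforhodamine B assay, with a stated time of 48 h (a lower number here means a stronger inhibitor of growth, a higher number a weaker inhibitor of growth), compound 1 gives 1030 nM, compound 2 gives 1010 nM and compound 3 gives 389 nM. Compound 2 therefore stands second highest of the three numbers, with compound 1 nearest and compound 3 furthest. For the measured compounds named here, the one measured single step, a 2.6-fold lower number from compound 2 to compound 3 (0.41 log units; beyond the scatter), concerns the urea end of the molecule and not the part changed here.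

Compound 4 `O=C(Nc1cccc(-n2cc(-c3ccncc3)c(-c3ccc(Cl)c(O)c3)n2)c1)Nc1ccc(Cl)c(C(F)(F)F)c1` differs from compound 2 by hydrogen in place of methyl on an oxygen on an aromatic ring. Going by the values given here, no measured step isolates this change. Compound 1, which also carries the hydroxy group but a different urea substituent, sits close to compound 2, so nothing seen so far points to a shift. The step from compound 2 to compound 4 is therefore expected to be a 1.0-fold lower number from compound 2 to compound 4 (0.00 log units; within the scatter), within the scatter. Compound 4 is estimated at 1000 nM in this assay, with a range from 500 nM to 2000 nM.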

Compound 4, concentration for 50% growth inhibition: 798 nM
Compound 4: the middle estimate sits 1.3-fold (0.10 log units) above what was measured; the measured number falls inside the stated range.
By their numbers in this assay, from the lowest: compound 3; then compounds 4, 2 and 1 (each within the scatter of the next).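

In this assay the swap of methoxy to hydroxy, with the urea kept the same, gives a 1.3-fold lower number from compound 2 to compound 4 (0.10 log units; within the scatter), so this position accepts either group without a difference that can be told from the scatter, something compound 1 and compound 2 could not show because they differ in two places. With the hydroxy kept, trifluoromethyl in place of chloro on an aromatic carbon gives a 1.3-fold lower number from compound 1 to compound 4 (0.11 log units; within the scatter), so the urea substituents of compound 1 and compound 4 also cannot be told apart here. No measurement is available that would explain either result.

Going by these compounds, whether the oxygen itself matters remains open, since an amine or a longer chain such as ethoxy in its place would test this. On these data alone, it is also open whether hydroxy in place of methoxy would read the same on the benzamide of compound 3.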